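Thiophene attachment swap in the series

The compounds below may be only part of what the source reports. "The series", "measured", "known", "first", "only" and "open" are said of these compounds alone.

Measured in a functional assay for inhibition, with Homo sapiens as the target (on this read-out lower numbers stand for stronger inhibition and higher numbers for weaker inhibition), so far:
- compound 1 `Cc1cccc(Nc2nccc(-c3ccc(C)o3)n2)c1` gives 2000 nM
- compound 2 `c1cc(Nc2nccc(-c3cccs3)n2)cc(-n2ccnc2)c1` gives 300 nM
- compound 3 `Cc1cccc(Nc2nccc(-c3ccsc3)n2)c1` gives 3800 nM

Compound 3 and compound 1 lie within the scatter of each other, and both lie beyond the scatter above compound 2. Compound 4 `Cc1cccc(Nc2nccc(-c3cccs3)n2)c1` carries thiophen-2-yl in place of thiophen-3-yl on an aromatic carbon. Among the measured compounds shown here, the only measured step at this place is a 1.9-fold higher number from compound 1 to compound 3 (0.28 log units; within the scatter) and it stayed within the scatter. Compound 2 also carries thiophen-2-yl, but it differs from compound 4 elsewhere, so it does not isolate this change. No step beyond the scatter is therefore expected in this assay for this swap, and the direction is only weakly indicated. The expected step is small (a 1.5-fold lower number from compound 3 to compound 4 (0.18 log units; within the scatter)). Compound 4 is estimated at 2500 nM (range 1000 nM to 6000 nM).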

Compound 4, half-maximal inhibitory concentration: 300 nM
Compound 4: the middle estimate sits 8.3-fold (0.92 log units) above what was measured, and the stated range ends above it.
By their numbers in this assay, from the lowest: compounds 2 and 4 (each within the scatter of the next); then compounds 1 and 3 (each within the scatter of the next).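

In this assay the attachment point of the thiophene counts: with the same atoms joined differently, thiophen-2-yl in place of thiophen-3-yl gives a 13-fold lower number from compound 3 to compound 4 (1.10 log units; beyond the scatter) on the shared core. Thiophen-2-yl in place of 5-methylfuran-2-yl also gives a step beyond the scatter, a 6.7-fold lower number from compound 1 to compound 4 (0.82 log units; beyond the scatter), which thiophen-3-yl did not show. Methyl in place of 1H-imidazol-1-yl gives no change at the digits printed from compound 2 to compound 4 (within the scatter), so that exchange leaves the read-out unmoved with thiophen-2-yl present.

Nothing at hand accounts for the gap between the two thiophene attachments. Open, going by these compounds, is whether an amine in place of the methyl keeps the read-out, and whether the thiophen-2-yl advantage holds with 1H-imidazol-1-yl present.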